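The source may report more compounds than this note shows. Statements on the series, on what has been measured and on what is new or still open speak of the compounds shown alone.

In a functional assay on NCI/ADR-RES cells (Homo sapiens) for inhibition, read by sulforhodamine B assay, with a stated time of 48 h (a higher number here means a weaker inhibitor of growth, a lower number a stronger inhibitor of growth), the measured compounds are:

Compound 1 `CC1(/C=C/c2ccccc2C(F)(F)F)C=CC(=O)O1`: 12200 nM
Compound 2 `COc1ccc(/C=C/C2(C)C=CC(=O)O2)c(OC)c1`: 151000 nM
Compound 3 `CC1(/C=C/c2ccccc2O)C=CC(=O)O1`: 78000 nM

Compound 3 lies within the scatter of compound 2, and both sit well above compound 1. The next compound is compound 4 `COc1ccccc1/C=C/C1(C)C=CC(=O)O1`, made from compound 3 by one small change: methyl in place of hydrogen on an oxygen on an aromatic ring. In words, methyl takes the place of hydrogen on an oxygen on an aromatic ring, turning hydroxy into methoxy.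

Going by the values given here, no measured step makes this exact change. The nearest evidence is a 6.4-fold higher number from compound 1 to compound 3 (0.81 log units; beyond the scatter), which replaced trifluoromethyl with the hydroxy now being altered. That shows the group at this place can matter, but it says little about a change as small as this one. Compound 2, which also carries methoxy, gives 151000 nM, close to compound 3. No clear shift is therefore expected in this assay, and the estimated step is a 1.0-fold higher number from compound 3 to compound 4 (0.01 log units; within the scatter), with neither direction favoured. For compound 4 the expected value is 80000 nM, with an estimated range of 28000 nM to 170000 nM.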

Compound 4, concentration for total growth inhibition: 64500 nM
Compound 4: middle estimate off by 1.2-fold (0.09 log units), on the high side; the measured number falls inside the stated range.
By their numbers in this assay, from the lowest: compound 1; then compounds 4, 3 and 2 (each within the scatter of the next, the first and the last beyond it).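

In this assay the swap of hydroxy for methoxy gives a 1.2-fold lower number from compound 3 to compound 4 (0.08 log units; within the scatter) and so leaves the number unchanged within the scatter, which means this hydrogen on the oxygen can give way to methyl without a readable effect. Methoxy in place of trifluoromethyl gives a 5.3-fold higher number from compound 1 to compound 4 (0.72 log units; beyond the scatter) and points the same way as the earlier hydroxy step, so both oxygen groups give higher numbers than trifluoromethyl. Taking away the extra methoxy gives a 2.3-fold lower number from compound 2 to compound 4 (0.37 log units; beyond the scatter) as a modest step beyond the scatter, so that group also has a measurable effect on the number.

No supporting measurement is available to explain these steps.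

Still open, going by these compounds, is whether an amine or a carboxylic acid at this place would give a number closer to that of methoxy or that of trifluoromethyl.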